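A few compounds are considered here, and "the series" means these few. Any claim that something is new, unique, unknown or untested is made for them only; others in the source may bear on it.

Compound 1 `Cn1c(-c2ccc(C#N)cc2)cnc1NC(=O)c1ccc(F)cc1` is one of three analogues characterised in a toxicity assay on THP-1 cells (Homo sapiens) for inhibition; on this read-out lower numbers stand for higher toxicity in this test and higher numbers for lower toxicity in this test. Compound 1 gives only a limit there, > 50000 nM. Compound 3 `Cn1c(-c2ccccc2Br)cnc1NC(=O)c1ccc(F)cc1` likewise gives only a limit in this assay, > 100000 nM. Compound 2 `COc1ccc(-c2noc(NC(=O)c3ccc(F)cc3)c2C)cc1` also returns only a limit, > 100000 nM. The step that the two limits leave unreadable from compound 1 to compound 3 is therefore unreadable, as both ends are limits; the values are summarised by the limit of > 100000 nM in this assay, at which 2 of the 3 values shown sit, and (the limit of > 50000 nM in this assay, at which 1 of the 3 values shown sits). Compound 4 `COc1ccc(-c2cnc(NC(=O)c3ccc(F)cc3)n2C)cc1` differs from compound 1 by methoxy in place of cyano on an aromatic carbon. For the measured compounds named here, no measured step bears on this change, and with every value shown sitting at a limit, no shift beyond the scatter is expected. Compound 4 is expected at 100000 nM (range 50000 nM to 300000 nM). The step that the limit leaves unreadable from compound 1 to compound 4 that this estimate means is expected to stay within the scatter.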

Compound 4, half-maximal cytotoxic concentration: >= 50000 nM
Compound 4 was reported as a limit (the forecaster's own chance of this, stated with the estimate: 85%); the middle value is on the limit's open side.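

Compound 4 also gives only a limit, so the steps to it from compound 1 and compound 3 cannot be read. With all four compounds at limits in this assay, the compounds shown leave open whether 4-cyanophenyl, 4-methoxyphenyl or 2-bromophenyl makes any difference.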